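Swapping Trifluoromethyl for Chloro on the Aryl Urea

The source may report more compounds than this note shows. Statements on the series, on what has been measured and on what is new or still open speak of the compounds shown alone.

Compound 1 `COc1cc2cc(Oc3ccc(NC(=O)Nc4cccc(C(F)(F)F)c4)cc3)c(C)nc2cc1OC` carries a urea whose outer ring bears a trifluoromethyl group. In a functional assay on HCT-15 cells (Homo sapiens) for inhibition, read by sulforhodamine B assay, with a stated time of 48 h (a higher number here means that more compound is tolerated, a lower number that less compound is tolerated), compound 1 gives only a limit, > 50000 nM. Among the compounds with values here, compound 2 `COc1cc2cc(Oc3ccc(NC(=O)Nc4ccc(Cl)c(C(F)(F)F)c4)cc3)c(C)nc2cc1OC` adds a chloro group to that ring; in this assay compound 2 gives 16900 nM, the only number among the two measured compounds. Within the data shown here, the step of an at least 2.9-fold lower number from compound 1 to compound 2 (0.47 log units; beyond the scatter) is the single measured change available. Compound 3 `COc1cc2cc(Oc3ccc(NC(=O)Nc4ccc(Cl)c(Cl)c4)cc3)c(C)nc2cc1OC` differs from compound 2 by chloro in place of trifluoromethyl on an aromatic carbon. Among the measured compounds shown here, no measured step tests the exchange of trifluoromethyl for chloro itself; the one step known concerns a chloro group entering where hydrogen stood, and it lowered the number. For the measured compounds named here, with that as the only guide, the step of a 1.2-fold higher number from compound 2 to compound 3 (0.07 log units; within the scatter) is expected to fall within the scatter. Compound 3 is therefore estimated at 20000 nM in this assay, with the range running from 7000 nM to 55000 nM.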

Compound 3, concentration lethal to 50% of the cells: > 100000 nM
Compound 3 gave a limit, no number; the forecaster's own chance of this, stated with the estimate: 20%; middle value at least 5.0-fold (0.69 log units) from the limit.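

Compound 3 gives a limit and not a number: the limit of > 100000 nM in this assay, at which 1 of the 3 values shown sits. In this assay, chloro in place of trifluoromethyl gives an at least 5.9-fold higher number from compound 2 to compound 3 (0.77 log units; beyond the scatter), so this position, ortho to a chloro group, does not treat the two groups alike. Among the three compounds, only compound 2, which carries both chloro and trifluoromethyl on the outer ring, gives a number rather than a limit, while compound 1 and compound 3 each lack one of these two groups.

The step between compound 1 and compound 3 cannot be read, as both ends are limits, and the true size of the step to compound 3 stays open for the same reason. From the compounds shown here alone, how a methyl, methoxy or nitrile group at this position would compare with trifluoromethyl also remains open.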